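From Fluoro to Nitro on the Benzyl Ether

The compounds below may be only part of what the source reports. "The series", "measured", "known", "first", "only" and "open" are said of these compounds alone.

In a functional assay on A-375 cells (Homo sapiens) for antiproliferative activity, read by MTT assay, with a stated time of 24 h (a lower number here means a stronger inhibitor, a higher number a weaker inhibitor), compound 1 `COc1cc(OC)c(-c2coc3cc(OCc4ccccc4)ccc3c2=O)cc1OC` gives 1640 nM and compound 3 `COc1cc(OC)c(-c2coc3cc(OCc4ccc(F)cc4)ccc3c2=O)cc1OC` gives 1720 nM, and a 1.0-fold higher number from compound 1 to compound 3 (0.02 log units; within the scatter) keeps the two within the scatter. Compound 2 `COc1cc(OC)c(-c2coc3cc(OCC(=O)c4cccc(C(F)(F)F)c4)ccc3c2=O)cc1OC` reads > 10000 nM, which is a limit of the assay. The steps of an at least 6.0-fold higher number from compound 1 to compound 2 (0.78 log units; beyond the scatter) and an at least 5.8-fold lower number from compound 2 to compound 3 (0.76 log units; beyond the scatter) rest on that limit and exchange a whole side group, so they bear only loosely on what follows. Compound 4 `COc1cc(OC)c(-c2coc3cc(OCc4ccc([N+](=O)[O-])cc4)ccc3c2=O)cc1OC` has nitro in place of fluoro on an aromatic carbon, para to a large group: nitro in place of fluoro on an aromatic carbon. For the measured compounds named here, the closest precedent is the substitution at that same carbon, a 1.0-fold higher number from compound 1 to compound 3 (0.02 log units; within the scatter), so no step beyond the scatter is expected, and the estimated step is a 1.2-fold higher number from compound 3 to compound 4 (0.07 log units; within the scatter). Compound 4 is estimated at 2000 nM, with an expected range of 700 nM to 6000 nM.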

Compound 4, half-maximal inhibitory concentration: > 10000 nM
Compound 4: a limit, no number; the forecaster's own chance of this, stated with the estimate: 10%; middle value at least 5.0-fold (0.69 log units) away from the limit.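

Compound 4 stands as a limit of the assay, not a number: the limit of > 10000 nM in this assay, at which 2 of the 4 values shown sit. Fluoro and hydrogen on this aromatic carbon had stayed within the scatter of each other, whereas nitro in the same place gives an at least 5.8-fold higher number from compound 3 to compound 4 (0.76 log units; beyond the scatter) and an at least 6.0-fold higher number from compound 1 to compound 4 (0.78 log units; beyond the scatter), so the position does respond to the group it carries. The step between compound 2 and compound 4 cannot be read, as both are limits.

On these data alone, how far compound 4 lies past the limit stays open. So does whether an amine or a nitrile on this carbon would read like fluoro or like nitro.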